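Removing the Chloro Group: Tolerance on Vero Cells

The source may report more compounds than this note shows. Statements on the series, on what has been measured and on what is new or still open speak of the compounds shown alone.

Compound 1 `COC(=O)/C=C1\Nc2cc(-c3ccccc3)ccc2OC1=O` carries a phenyl group on the shared core, but in an ADME assay on Vero cells (Chlorocebus sabaeus) for cytotoxicity, read by MTT assay, with a stated time of 72 h (a higher number here means that more compound is tolerated, a lower number that less compound is tolerated), compound 1 gives "not determined" (no result reported), so no result was obtained for it. Within the data shown here, compound 2 `COC(=O)/C=C1\Nc2cc(Cl)ccc2OC1=O` carries chloro instead; in this assay compound 2 gives 1630000 nM, the only number available, so it stands alone. Compound 3 `COC(=O)/C=C1\Nc2ccccc2OC1=O` differs from compound 2 in one place: hydrogen in place of chloro on an aromatic carbon. Among the measured compounds shown here, no measured step guides the size, so a change within the usual scatter is expected, if anything toward more compound tolerated. Compound 3 is estimated at 2000000 nM, between 800000 nM and 5000000 nM, an expected step of a 1.2-fold higher number from compound 2 to compound 3 (0.09 log units; within the scatter).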

Compound 3, half-maximal cytotoxic concentration: > 2280000 nM
Compound 3: a limit, no number; the forecaster's own chance of this, stated with the estimate: 30%; at least 1.1-fold (0.05 log units) between middle value and limit.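

Compound 3 gives a limit of the assay, not a number, in this assay: the limit of > 2280000 nM in this assay, at which 1 of the 3 values shown sits.

On this aromatic carbon, hydrogen in place of chloro gives an at least 1.3-fold higher number from compound 2 to compound 3 (0.14 log units; that floor lies within the scatter). Taking away the chloro group therefore brings no drop in the number here, but only a floor for the step is known and its true size remains open.

Compound 1 gives no number, so phenyl at this position cannot be set against chloro or hydrogen. As far as these compounds go, how an amine or a carboxylic acid on this carbon would read in this assay also stays open.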